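Swapping Fluoro for Methyl on a Weak Thiourea Analogue

The source may hold more compounds than are shown below. What is called first, only, known or untested is meant among the compounds shown, and "the series" means these compounds.

Within the data shown here, compound 2 `NS(=O)(=O)c1ccc(NC(=S)Nc2ccc3ncnc(Nc4cccc(F)c4)c3c2)cc1` is one of two compounds measured in a functional assay on A-431 cells (Homo sapiens) for antiproliferative activity, read by MTT assay, with a stated time of 72 h; a lower number here means a stronger inhibitor, a higher number a weaker inhibitor. There compound 2 gives 30100 nM, the highest of the two numbers. Its closest relative, compound 1 `C#Cc1cccc(Nc2ncnc3ccc(NC(=S)Nc4ccc(S(N)(=O)=O)cc4)cc23)c1`, gives 15300 nM in this assay, and the step of a 2.0-fold higher number from compound 1 to compound 2 (0.29 log units; within the scatter) shows that the two stand within the scatter of each other, so neither can be called the weaker. Compound 3 `Cc1cccc(Nc2ncnc3ccc(NC(=S)Nc4ccc(S(N)(=O)=O)cc4)cc23)c1` is not yet measured. It differs from compound 2 in one place: methyl in place of fluoro on an aromatic carbon. Among the measured compounds shown here, the only measured step touching this same position is a 2.0-fold higher number from compound 1 to compound 2 (0.29 log units; within the scatter), which stayed within the scatter, so a change at this spot has so far left the number essentially unmoved. On that basis compound 3 is expected to show no step beyond the scatter, an expected step of a 1.2-fold lower number from compound 2 to compound 3 (0.08 log units; within the scatter). In this assay compound 3 is therefore estimated at 25000 nM, in a range from 9000 nM to 70000 nM.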

Compound 3, half-maximal inhibitory concentration: 23800 nM
For compound 3 the middle estimate is 1.1-fold (0.02 log units) above the measured one; low and high end bracket the measured number.
By their numbers in this assay, from the lowest: compounds 1, 3 and 2 (each within the scatter of the next).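

In this assay, methyl in place of fluoro gives a 1.3-fold lower number from compound 2 to compound 3 (0.10 log units; within the scatter) when read on its own, and methyl in place of ethynyl gives a 1.6-fold higher number from compound 1 to compound 3 (0.19 log units; within the scatter) for the second comparison. A single step at this position has now become three steps among three groups, ethynyl, fluoro and methyl, and every one of them stays within the scatter, so no group can be ranked above another here. Nothing measured on these compounds offers an explanation for this flat result.

Still open, from the compounds shown here alone, is whether an amine, a carboxylic acid or a longer chain on this aromatic carbon would move the number beyond the scatter. The compounds shown also leave open whether a change elsewhere in the shared structure would do so.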